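Series notes: aryl swap from compound 2 to compound 3

This account rests on a few compounds, and the source may have more. Where it says the series, first, only, none or still open, it means among the compounds named here.

Measured so far:
compound 1, `COc1cccc(NC(=O)CSc2nc(Nc3ccccc3)c3ccccc3n2)c1`: 11600 nM
compound 2, `C=CC(=O)Nc1cccc(NC(=O)CSc2nc(Nc3ccccc3Br)c3ccccc3n2)c1`: 17100 nM

Both numbers come from a functional assay on PC-3 cells (Homo sapiens) for inhibition, read by MTT assay, with a stated time of 72 h; a lower number here means a stronger inhibitor, a higher number a weaker inhibitor. Compound 2 holds the higher of the two values, but its gap to compound 1 lies within the scatter, so the two compounds cannot be ordered on these data. Compound 3, `C=CC(=O)Nc1cccc(NC(=O)CSc2nc(Nc3ccc(F)cc3)c3ccccc3n2)c1`, is not yet measured. It differs from compound 2 in one place: 4-fluorophenyl in place of 2-bromophenyl on a nitrogen on an aromatic ring. Within the data shown here, no step of this kind has been measured, so no direction beyond the scatter is expected. The step of a 1.3-fold lower number from compound 2 to compound 3 (0.12 log units; within the scatter) is the estimated size. Compound 3 is expected to give about 13000 nM in this assay, within 5000 nM to 35000 nM.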

Compound 3, half-maximal inhibitory concentration: 8240 nM
Beside the measured number, compound 3's estimate is 1.6-fold (0.20 log units) above it; low and high end bracket the measured number.
By their numbers in this assay, from the lowest: compounds 3, 1 and 2 (each within the scatter of the next, the first and the last beyond it).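

In this assay, among these compounds, putting 4-fluorophenyl in place of 2-bromophenyl on the nitrogen gives a 2.1-fold lower number from compound 2 to compound 3 (0.32 log units; beyond the scatter) as the only measured single-place step. It shows that the number responds to the aryl group at this position, though modestly. No measured evidence bears on the reason for this step.
Halogen identity and halogen placement change together here, so the compounds shown leave open which of them carries the step. Also open, going by these compounds, is how an aminophenyl or carboxyphenyl group would read at this position.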